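The source may hold more compounds than are shown below. What is called first, only, known or untested is meant among the compounds shown, and "the series" means these compounds.

Of the compounds shown here, two have been measured in a functional assay on the whole organism for inhibition of sodium-dependent dopamine transporter (Mus musculus); a lower number here means that less compound is needed, a higher number that more compound is needed for the effect. Compound 1, `CCCCNC(=O)Nc1cccc2c1CN(C)CC2c1ccc(Cl)cc1`, carries a chloro group on its pendant aromatic ring and a butylurea on the shared core; in this assay compound 1 gives about 120 mg/kg. Compound 2, `CCNCC(=O)Nc1cccc2c1CN(C)CC2c1ccccc1`, has an unsubstituted phenyl group and an ethylaminoacetamide instead; in this assay compound 2 gives about 60 mg/kg. For the measured compounds named here, of the two numbers, the one for compound 2 is the lower, yet the gap to compound 1 lies within the scatter, so no real difference between the two is established. Since these compounds differ in two places at once, no single change can be read from them.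

Compound 3, `CCNCC(=O)Nc1cccc2c1CN(C)CC2c1ccc(Cl)cc1`, has not yet been measured. It differs from compound 2 in one place: chloro in place of hydrogen on an aromatic carbon, para to a large group, so that a phenyl group becomes a 4-chlorophenyl group. Going by the values given here, no measured pair shows this change on its own. Among the compounds with values here, the only hint is that compound 1, which carries the same chloro group alongside a different side chain, gives about 120 mg/kg, a number within the scatter of compound 2. In this assay compound 3 is therefore expected to land close to compound 2. The expected step, a 1.1-fold lower number from compound 2 to compound 3 (0.04 log units; within the scatter), does not reach beyond the scatter. The estimate for compound 3 is 55 mg/kg, with a range from 25 mg/kg to 120 mg/kg.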

Compound 3, dose for half-maximal effect: about 25 mg/kg
Estimate against measurement, compound 3: 2.2-fold (0.34 log units) above; the range from low to high includes it.
By their numbers in this assay, from the lowest: compound 3; then compounds 2 and 1 (each within the scatter of the next).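

In this assay, the chloro group can now be read on its own: with the side chain held fixed, chloro in place of hydrogen on the aromatic carbon, para to a large group, gives a 2.4-fold lower number from compound 2 to compound 3 (0.38 log units; beyond the scatter), so less compound is needed once phenyl becomes 4-chlorophenyl. With the 4-chlorophenyl group held fixed, the side chain also matters: (ethylamino)methyl in place of butylamino on the carbonyl carbon gives a 4.8-fold lower number from compound 1 to compound 3 (0.68 log units; beyond the scatter), an effect that the earlier pair, which differed in two places at once, could not separate. No further measurement is available to explain either step.

Going by these compounds, it remains open whether this gain belongs to chlorine in particular, which fluoro, bromo, methyl or methoxy at the same place would help to test. On these data alone, it is also open whether the chloro step carries over to other side chains, which would take the phenyl partner of compound 1 to test, and whether a longer amine chain in place of the ethylamino group would lower the number further.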